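A few compounds are considered here, and "the series" means these few. Any claim that something is new, unique, unknown or untested is made for them only; others in the source may bear on it.

Compound 2 `CN(C(=S)SCc1ccc(C(=O)Nc2ccccc2N)cc1)c1cccnc1` carries the shared core of this small set, and in a functional assay on MGC-803 cells (Homo sapiens) for antiproliferative activity, read by CCK-8 assay, with a stated time of 72 h, tested at 8 uM (on this read-out higher numbers stand for a stronger effect at the one concentration tested and lower numbers for a weaker effect), compound 2 gives 82.5%. Its companion, compound 1 `Nc1ccccc1NC(=O)c1ccc(CSC(=S)N2CCc3ccccc32)cc1`, gives 87% in this assay, and the two numbers lie within the usual scatter of each other, so neither can be called the stronger of the pair.

The step to compound 3 `Nc1ccccc1NC(=O)c1ccc(CSC(=S)N2CCCc3ccccc32)cc1` is 1,2,3,4-tetrahydroquinolin-1-yl in place of methyl(pyridin-3-yl)amino on a thiocarbonyl carbon. Going by the values given here, the only measured step that bears on it is the one from compound 1 to compound 2, where a number 4.5 percentage points lower from compound 1 to compound 2 (within the scatter), which shows that swapping the group on the thiocarbonyl carbon left the read-out essentially unchanged. With that in view, no step beyond the scatter is expected in this assay, and the step from compound 2 to compound 3 is estimated as a number 3.5 percentage points higher from compound 2 to compound 3 (within the scatter). Compound 3 is therefore expected to give about 86% in this assay, with a plausible range from 74% to 95%.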

Compound 3, a percentage reported as inhibition, at one concentration (the size of the read-out at that concentration, not a potency): 87.5%
For compound 3 the middle estimate is 1.5 percentage points below the measured one; measured number inside the range.
By their numbers in this assay, from the lowest: compounds 2, 1 and 3 (each within the scatter of the next).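

In this assay, 1,2,3,4-tetrahydroquinolin-1-yl in place of methyl(pyridin-3-yl)amino gives a number 5 percentage points higher from compound 2 to compound 3 (within the scatter), and the same group in place of 2,3-dihydro-1H-indol-1-yl gives a number 0.5 percentage points higher from compound 1 to compound 3 (within the scatter). All three groups on this thiocarbonyl carbon therefore give numbers that cannot be told apart, even though the hydrogen-bond acceptor counted for methyl(pyridin-3-yl)amino is absent from 1,2,3,4-tetrahydroquinolin-1-yl, and its hetero-atom aromatic ring gives way to an aromatic ring of carbon only. Nothing given here explains why these numbers stay so close.

Open, on these data alone, is whether a small open-chain group such as diethylamino, or a group carrying a carboxylic acid, would stay within the scatter at this place. Also open, as far as these compounds go, is whether the three compounds would show a stronger or weaker effect than one another at other concentrations, which a reading at one concentration does not give.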